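Morpholine for Pyrrolidine: Two Cores, One Compound Awaiting Measurement

The source may report more compounds than this note shows. Statements on the series, on what has been measured and on what is new or still open speak of the compounds shown alone.

Of the compounds shown here, three have been measured in a functional assay on MDA-MB-435S cells (Homo sapiens) for antiproliferative activity, read by MTT assay, with a stated time of 72 h; a higher number here means a weaker inhibitor, a lower number a stronger inhibitor. Compound 1 `O=c1cc(CSC(=S)N2CCCC2)oc2cc(Cl)ccc12` and compound 2 `O=c1cc(CSC(=S)N2CCOCC2)oc2cc(Cl)ccc12` share one core; compound 3 `O=c1c(Cl)c(CSC(=S)N2CCCC2)oc2ccccc12` and the as yet unmeasured compound 4 `O=c1c(Cl)c(CSC(=S)N2CCOCC2)oc2ccccc12` share another, and the difference between the two cores is not broken down here. In this assay compound 1 gives > 25000 nM, which is a limit of the assay rather than a number. Compound 2 likewise gives > 25000 nM, again only a limit. Going by the values given here, compound 3 gives 1800 nM, the single number among the three. The change from compound 1 to compound 2 is morpholin-4-yl in place of pyrrolidin-1-yl on a thiocarbonyl carbon, and its step, a step that the two limits leave unreadable from compound 1 to compound 2, cannot be read because both values sit at the limit of > 25000 nM in this assay, at which 2 of the 3 values shown sit. The change from compound 3 to compound 4 is morpholin-4-yl in place of pyrrolidin-1-yl on a thiocarbonyl carbon, the same change at the same place. The measured instance of this change therefore gives no direction. The step from compound 3 to compound 4 is expected to be a 1.9-fold higher number from compound 3 to compound 4 (0.29 log units; within the scatter). That expectation rests on the value of compound 3, 1800 nM, with a wide allowance either way. Compound 4 is thus expected to give about 3500 nM, between 1200 nM and 15000 nM.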

Compound 4, half-maximal inhibitory concentration: 4100 nM
Beside the measured number, compound 4's estimate is 1.2-fold (0.07 log units) below it; measured number inside the range.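

In this assay, morpholin-4-yl in place of pyrrolidin-1-yl on a thiocarbonyl carbon gives a 2.3-fold higher number from compound 3 to compound 4 (0.36 log units; beyond the scatter), a modest loss of activity on the core that these two compounds share. On the core shared by compound 1 and compound 2, the same change cannot be read, because both compounds give a limit of the assay and not a number: the limit of > 25000 nM in this assay, at which 2 of the 4 values shown sit. The change therefore has a readable size and direction on one core only, and nothing here shows whether either carries over to the other core, so one step establishes no pattern across the series.

The compounds shown leave open whether the loss of activity follows from the oxygen that morpholin-4-yl brings or from the larger ring, a question that piperidine on the same thiocarbonyl carbon could separate. They also leave open how an open-chain amine such as diethylamine would compare with either ring in that place.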